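A few compounds are considered here, and "the series" means these few. Any claim that something is new, unique, unknown or untested is made for them only; others in the source may bear on it.

Compound 1 `Clc1ccc(COc2ccccc2/C=C/C(/C=C/c2ccccn2)=N/Oc2ncnc3cc(Cl)ccc23)c(Cl)c1` gives 23.6% in a functional assay on SMMC-7721 cells (Homo sapiens) for inhibition, read by MTT assay, with a stated time of 72 h, tested at 1 uM; a lower number here means a weaker effect, a higher number a stronger effect of the compound at the concentration tested. Compound 2 `Clc1ccc2c(O/N=C(/C=C/c3ccc(OCc4ccccc4Cl)cc3)\C=C\c3ccccn3)ncnc2c1` gives 18.1% in this assay, and the two numbers lie within the usual scatter of each other, so compound 1 is not set apart from compound 2 by the data available. Compound 3 `Fc1ccccc1COc1ccccc1/C=C/C(/C=C/c1ccccn1)=N/Oc1ncnc2cc(Cl)ccc12` has not yet been measured in this assay; it differs from compound 1 by 2-fluorophenyl in place of 2,4-dichlorophenyl on a saturated chain carbon bound to an oxygen on an aromatic ring. For the measured compounds named here, no measured step of this kind exists to lean on, so the step of a number 5.6 percentage points lower from compound 1 to compound 3 (within the scatter) is expected to be small, if anything slightly downward, and within the scatter. Compound 3 is estimated to give 18% in this assay, within 7% to 32%.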

Compound 3, a percentage reported as inhibition, at one concentration (the size of the read-out at that concentration, not a potency): 94.2%
Estimate against measurement, compound 3: 76.2 percentage points below; measured number above the stated range.
By their numbers in this assay, from the lowest: compounds 2 and 1 (each within the scatter of the next); then compound 3.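

In this assay, the place on a saturated chain carbon bound to an oxygen on an aromatic ring proves highly sensitive: 2-fluorophenyl in place of 2,4-dichlorophenyl gives a large step (a number 70.6 percentage points higher from compound 1 to compound 3 (beyond the scatter)). The earlier compounds shown here, with no step between them, gave no sign of this. No evidence at hand accounts for the step.

The compounds shown leave open whether the rise follows the loss of chlorine or the arrival of fluorine. From the compounds shown here alone, how plain phenyl or 2-chlorophenyl would read at this place also remains open.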